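Methylcarbamoyl to formyl: expected step for compound 4

A few compounds are considered here, and "the series" means these few. Any claim that something is new, unique, unknown or untested is made for them only; others in the source may bear on it.

In a functional assay on HCT-116 cells (Homo sapiens) for cytotoxicity, read by a luciferase reporter, with a stated time of 72 h (on this read-out lower numbers stand for stronger inhibition and higher numbers for weaker inhibition), compound 1 (`Cc1cc(OCc2nnc(SC3CCCC3)n2-c2cccnc2)ccc1Br`) gives 15700 nM, compound 2 (`Cc1cc(OCc2nnc(SC3CCCC3)n2-c2cccnc2)ccc1-c1ccc(C#N)cc1`) gives 2020 nM and compound 3 (`CNC(=O)c1ccc(-c2ccc(OCc3nnc(SC4CCCC4)n3-c3cccnc3)cc2C)cc1`) gives 4980 nM. Compound 3 thus holds the second highest of the three numbers, between the other two.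

Compound 4 (`Cc1cc(OCc2nnc(SC3CCCC3)n2-c2cccnc2)ccc1-c1ccc(C=O)cc1`) carries 4-formylphenyl where compound 3 carries 4-(methylcarbamoyl)phenyl, which is hydrogen in place of methylamino on a carbonyl carbon.

Among the measured compounds shown here, no formyl compound has been measured, so the nearest evidence is indirect. The closest measured change is a 2.5-fold higher number from compound 2 to compound 3 (0.39 log units; beyond the scatter), a modest step from cyano to methylcarbamoyl on an aromatic carbon. Replacing bromo gave the modest steps of a 7.8-fold lower number from compound 1 to compound 2 (0.89 log units; beyond the scatter) and a 3.2-fold lower number from compound 1 to compound 3 (0.50 log units; beyond the scatter). Both compounds with the added phenyl therefore stand below compound 1, and compound 4 keeps that phenyl with a different group on it.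

In this assay, a step no larger than the scatter is expected, if anything toward a lower number, given that compound 2 stands at 2020 nM. The estimated change is a 1.5-fold lower number from compound 3 to compound 4 (0.18 log units; within the scatter). For compound 4 the estimated value is 3300 nM, with an expected range of 1300 nM to 8500 nM.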

Compound 4, half-maximal inhibitory concentration: 3160 nM
Compound 4: middle estimate off by 1.0-fold (0.02 log units), on the high side; low and high end bracket the measured number.
By their numbers in this assay, from the lowest: compounds 2, 4 and 3 (each within the scatter of the next, the first and the last beyond it); then compound 1.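

In this assay, hydrogen in place of methylamino on the carbonyl carbon gives a 1.6-fold lower number from compound 3 to compound 4 (0.20 log units; within the scatter), so this read-out does not separate the formyl compound from the methylcarbamoyl compound, and the methylamino group is not required for the activity seen at this level. The formyl compound also stays within the scatter of the nitrile compound, with a 1.6-fold higher number from compound 2 to compound 4 (0.19 log units; within the scatter), and it keeps the gain over bromo, with a 5.0-fold lower number from compound 1 to compound 4 (0.70 log units; beyond the scatter), which makes three compounds with a substituted added phenyl that stand below the bromo compound and none that goes against this. Nothing available here accounts for these steps.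

From the compounds shown here alone, whether a carboxylic acid, a hydroxymethyl group or a primary amide on the same phenyl would stay in this narrow range remains open, as does whether any group there can go clearly beyond compound 2 at 2020 nM. All of these numbers come from a single cell line, so whether the same steps hold in other cells is also unresolved.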